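Phenyl directly on the amide nitrogen of the series

The source may report more compounds than this note shows. Statements on the series, on what has been measured and on what is new or still open speak of the compounds shown alone.

Compound 3 `Cc1nc(N)sc1CCCN/C(N)=N/C(=O)NC(C)c1cccs1` gives 63.1 nM in an assay on membranes from Sf9 cells for displacement of a labelled ligand from histamine H2 receptor (Homo sapiens), read by scintillation counting, with a stated time of 60 min (a higher number here means a weaker inhibitor, a lower number a stronger inhibitor), the second highest of the three numbers recorded. Compound 1 `CCCNC(=O)/N=C(\N)NCCCc1sc(N)nc1C` gives 105 nM in this assay, and the pair are separated only by a 1.7-fold lower number from compound 1 to compound 3 (0.22 log units; within the scatter). Compound 2 `Cc1nc(N)sc1CCCN/C(N)=N/C(=O)NCc1ccco1` gives 10.5 nM in this assay and is the furthest from compound 3, by a 6.0-fold higher number from compound 2 to compound 3 (0.78 log units; beyond the scatter).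

Compound 4 `Cc1nc(N)sc1CCCN/C(N)=N/C(=O)Nc1ccccc1` is not yet measured. It differs from compound 3 by phenyl in place of 1-(thiophen-2-yl)ethyl on an amide-type nitrogen. For the measured compounds named here, the steps that bear on this change are the three at the same nitrogen: a 10-fold lower number from compound 1 to compound 2 (1.00 log units; beyond the scatter), a 1.7-fold lower number from compound 1 to compound 3 (0.22 log units; within the scatter) and a 6.0-fold higher number from compound 2 to compound 3 (0.78 log units; beyond the scatter). An aromatic ring on this nitrogen is tolerated; the (furan-2-yl)methyl group gives the lowest number recorded, whereas the branched 1-(thiophen-2-yl)ethyl group sits close to propyl. Going by the values given here, no measured compound carries an aromatic ring directly on the nitrogen, so a phenyl there has no direct precedent, and the estimate must stay wide. Removing the saturated chain carbon that carries the ring is expected to move compound 4 modestly toward compound 2, by a 1.6-fold lower number from compound 3 to compound 4 (0.20 log units; within the scatter). Compound 4 is therefore estimated at 40 nM in this assay, with a range from 12 nM to 150 nM.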

Compound 4, inhibition constant: 3160 nM
The estimate for compound 4 lay 79-fold (1.90 log units) below the measured number, and the stated range ends below it.
By their numbers in this assay, from the lowest: compound 2; then compounds 3 and 1 (each within the scatter of the next); then compound 4.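

In this assay, for the compounds shown here, a phenyl group directly on the amide-type nitrogen gives steps larger than any among the earlier compounds: a 50-fold higher number from compound 3 to compound 4 (1.70 log units; beyond the scatter), a 300-fold higher number from compound 2 to compound 4 (2.48 log units; beyond the scatter) and a 30-fold higher number from compound 1 to compound 4 (1.48 log units; beyond the scatter). Compounds 1, 2 and 3 all keep a saturated chain carbon on this nitrogen, and compound 4 alone lacks it, so the tolerance seen for a propyl, (furan-2-yl)methyl or 1-(thiophen-2-yl)ethyl group does not extend to every aromatic group at this position. Nothing available explains the size of these steps.

Compound 4 differs from compounds 2 and 3 both in lacking the saturated chain carbon and in carrying a six-membered aromatic ring of carbon only, and the compounds shown do not separate these two changes. A benzyl group on this nitrogen would test the six-membered ring with the saturated carbon kept, while a furan-2-yl or thiophen-2-yl ring bound directly to the nitrogen would test the loss of that carbon with a five-membered ring kept.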